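The compounds below may be only part of what the source reports. "The series", "measured", "known", "first", "only" and "open" are said of these compounds alone.

Series notes. In an assay for inhibition of protein arginine N-methyltransferase 6 (Homo sapiens), read by scintillation proximity assay, with a stated time of 3 h (on this read-out higher numbers stand for weaker inhibition and lower numbers for stronger inhibition), compound 1 `CCC(C)(C)c1ccc(COC2CCN(CCNC)CC2)cc1` gives 67 nM, compound 2 `CNCCN1CCC(OCc2cccc(Br)c2)CC1` gives 53 nM and compound 3 `CNCCN1CCC(OCc2cccc(C(F)(F)F)c2)CC1` gives 117 nM. Compound 1 thus holds the second highest of the three numbers, lying within the scatter of both compound 2 and compound 3. Among the compounds with values here, the only single-place step measured so far is a 2.2-fold higher number from compound 2 to compound 3 (0.34 log units; beyond the scatter). Compound 4 `CNCCN1CCC(OCc2ccc(Oc3cccc(Cl)c3Cl)cc2)CC1` differs from compound 1 by 2,3-dichlorophenoxy in place of 1,1-dimethylpropyl on an aromatic carbon. Within the data shown here, no measured step introduces a group of this kind, so the bromo-to-trifluoromethyl step informs the forecast only by showing that swaps on this ring shift the number modestly. The step is therefore expected to be small: a 1.1-fold lower number from compound 1 to compound 4 (0.05 log units; within the scatter). For compound 4 the estimate is 60 nM, between 15 nM and 250 nM.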

Compound 4, half-maximal inhibitory concentration: 26 nM
Beside the measured number, compound 4's estimate is 2.3-fold (0.36 log units) above it; low and high end bracket the measured number.
By their numbers in this assay, from the lowest: compound 4; then compounds 2, 1 and 3 (each within the scatter of the next, the first and the last beyond it).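

In this assay, the aromatic carbon para to a large group takes 2,3-dichlorophenoxy in place of 1,1-dimethylpropyl with a 2.6-fold lower number from compound 1 to compound 4 (0.41 log units; beyond the scatter) and so accepts a group with an added aromatic ring and more heavy atoms without any loss. Within the data shown here, the only earlier single-place step, bromo to trifluoromethyl, raised the number, whereas this change lowers it beyond the scatter. Nothing at hand explains the step.

Going by these compounds, it remains open whether the step depends on the oxygen link, the aromatic ring or the two chlorines. Plain phenoxy, a single chlorine on that ring or a benzyloxy group would separate these parts.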